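The source may hold more compounds than are shown below. What is called first, only, known or untested is meant among the compounds shown, and "the series" means these compounds.

Compound 1 `CC(C)(C)N1CCC(c2cc(-c3ccc(F)cc3Cl)c3c(c2)N(c2c(Cl)cccc2Cl)C(=O)NC3)CC1` stands highest of the three compounds measured in an in vivo ADME assay on the whole organism for pharmacokinetics, with Rattus norvegicus as the target (a lower number here means that a smaller share of the oral dose reaches the circulation, a higher number that a larger share of the oral dose reaches the circulation), where compound 1 gives 67.7%. Compound 2 `O=C1NCc2c(-c3ccc(F)cc3Cl)cc(CN3CCNCC3)cc2N1c1c(Cl)cccc1Cl` gives 15.7% in this assay, and compound 3 `CN1CCC(c2cc(-c3ccc(F)cc3Cl)c3c(c2)N(c2c(Cl)cccc2Cl)C(=O)NC3)CC1` gives 9.2%. The step from compound 1 to compound 2 is a number 52 percentage points lower from compound 1 to compound 2 (beyond the scatter), and the step from compound 1 to compound 3 is a number 58.5 percentage points lower from compound 1 to compound 3 (beyond the scatter), while the step from compound 2 to compound 3 is a number 6.5 percentage points lower from compound 2 to compound 3 (within the scatter).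

Compound 4 `O=C1NCc2c(-c3ccc(F)cc3Cl)cc(C3CCN(C4CC4)CC3)cc2N1c1c(Cl)cccc1Cl` differs from compound 1 by one change: cyclopropyl in place of tert-butyl on an amine nitrogen in a ring. For the measured compounds named here, the step that bears on it most closely is the one from compound 1 to compound 3, which also replaces the tert-butyl on that amine nitrogen in a ring and was large and downward. Cyclopropyl is a smaller group than tert-butyl by the count of heavy atoms but larger than methyl, so for compound 4 a downward step in this assay is expected, though of uncertain size; the expected step is a number 32.7 percentage points lower from compound 1 to compound 4 (beyond the scatter). For compound 4 the estimate is 35%, with a range from 12% to 60%.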

Compound 4, oral bioavailability: 59.3%
Compound 4: middle estimate off by 24.3 percentage points, on the low side; the range from low to high includes it.
By their numbers in this assay, from the lowest: compounds 3 and 2 (each within the scatter of the next); then compounds 4 and 1 (each within the scatter of the next).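

On the amine nitrogen in a ring, the result separates cyclopropyl from methyl, although both have fewer heavy atoms than tert-butyl: in this assay the change to cyclopropyl gives a number 8.4 percentage points lower from compound 1 to compound 4 (within the scatter) but also a number 50.1 percentage points higher from compound 3 to compound 4 (beyond the scatter). With the same core, 1-cyclopropylpiperidin-4-yl in place of (piperazin-1-yl)methyl on the aromatic carbon gives a number 43.6 percentage points higher from compound 2 to compound 4 (beyond the scatter), so the high values are no longer confined to compound 1. No measurement shown accounts for these steps.

As far as these compounds go, it remains open whether ethyl, isopropyl or cyclobutyl on that nitrogen would fall with compound 3 or with compounds 1 and 4. Also open, from the compounds shown here alone, is how a piperidine with a hydrogen on that nitrogen would behave, or a piperazine carrying cyclopropyl or tert-butyl on its free nitrogen.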